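The source may hold more compounds than are shown below. What is called first, only, known or untested is meant among the compounds shown, and "the series" means these compounds.

Measured compounds:
Compound 1, `C=CCn1c(=O)n([C@@H]2O[C@H](CO)[C@H]3OC(CCC)(CCC)O[C@H]32)c2nc(N)nc(O)c21`: 38%
Compound 2, `COc1ccc(Cn2c(=O)n(C3OC(CO)[C@@H](O)[C@H]3O)c3nc(N)nc(O)c32)cc1`: 14%
Compound 3, `C=CCn1c(=O)n([C@@H]2O[C@H](CO)[C@H]3OC(=O)O[C@H]32)c2nc(N)nc(O)c21`: 97%

All three were tested in a functional assay on the whole organism with Mus musculus as the target; on this read-out higher numbers stand for larger maximal responses and lower numbers for smaller maximal responses. Compound 2 stands at the bottom of the three numbers: its nearest neighbour is compound 1, whose largest response lies beyond the usual scatter above it, and the furthest is compound 3, whose largest response lies far above it. Among the compounds with values here, no pair among the measured compounds differs in only one place, so no single change can be followed directly from these numbers.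

The step of interest leads from compound 2 to compound 4, `NC(=O)Cn1c(=O)n(C2OC(CO)[C@@H](O)[C@H]2O)c2nc(N)nc(O)c21`, which has not yet been measured in this assay. The change is carbamoyl in place of 4-methoxyphenyl on a saturated chain carbon bound to an aromatic nitrogen. The measured set holds no comparison in which the group on the saturated chain carbon bound to the aromatic nitrogen is varied while the rest of the molecule is kept, so the size and direction of this step are not anchored by any shown pair.

Given the low position of compound 2, a moderate rise from compound 2 to compound 4 is expected, a number 21 percentage points higher from compound 2 to compound 4 (beyond the scatter), though a change no larger than the scatter is also plausible. Compound 4 is therefore estimated to reach 35% in this assay, with a range from 8% to 75%.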

Compound 4, largest response reached (reported as maximal response), in percent of the reference or control that the assay uses: 72%
Beside the measured number, compound 4's estimate is 37 percentage points below it; low and high end bracket the measured number.
By their numbers in this assay, from the lowest: compound 2; then compound 1; then compound 4; then compound 3.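

In this assay, within the data shown here, carbamoyl in place of 4-methoxyphenyl on a saturated chain carbon bound to an aromatic nitrogen gives a number 58 percentage points higher from compound 2 to compound 4 (beyond the scatter) and provides the first direct reading at this position, where the rest of the molecule stays the same. It shows that the maximal response depends strongly on the group at this position and that, with this core, the six-membered aromatic ring of the 4-methoxybenzyl group is not needed for a large response, since carbamoylmethyl, which has no ring, gives a far larger one. No measurement shown here explains the size of this step.

This single step changes the ring, the size of the group and the amide hydrogen together, so the compounds shown do not separate what each of these contributes, and they do not show whether an unsubstituted benzyl group would stay as low as 4-methoxybenzyl. Nor do they show whether the large response persists when carbamoyl gives way to a carboxylic acid, an amine or a longer chain ending in carbamoyl, or whether this step would have the same size on the cores of the other compounds.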